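This account rests on a few compounds, and the source may have more. Where it says the series, first, only, none or still open, it means among the compounds named here.

Compound 1 `COc1ccc(/C=N/NC(=O)c2ccc(O[C@@H]3O[C@H](CO)[C@@H](O)[C@H](O)[C@H]3O)cc2)cc1` gives 11.3% in a functional assay on MDA-MB-231 cells (Homo sapiens) for inhibition, read by MTT assay, with a stated time of 24 h, tested at 100 uM; a lower number here means less inhibition, a higher number more inhibition at the concentration tested (going by the name of the read-out).
Compound 2 `O=C(N/N=C/c1cccc(Cl)c1)c1ccc(O[C@@H]2O[C@H](CO)[C@@H](O)[C@H](O)[C@H]2O)cc1` gives 5.02% in this assay.
Compound 3 `O=C(N/N=C/c1ccccc1)c1ccc(O[C@@H]2O[C@H](CO)[C@@H](O)[C@H](O)[C@H]2O)cc1` gives 3.56% in this assay.

Compound 3 carries the smallest of the three numbers, but its gaps to the others, a number 1.5 percentage points lower from compound 2 to compound 3 (within the scatter) and a number 7.7 percentage points lower from compound 1 to compound 3 (within the scatter), lie within the scatter, so the three measured compounds sit together at low inhibition. Compound 4 `CC(C)/C=N/NC(=O)c1ccc(O[C@@H]2O[C@H](CO)[C@@H](O)[C@H](O)[C@H]2O)cc1` differs from compound 3 by isopropyl in place of phenyl on a carbon with a double bond to nitrogen. Among the measured compounds shown here, the measured steps only swap substituents on the phenyl and none removes the ring, so no step bears directly on this change; they do show that variation at this position has so far left the read-out low. No step beyond the scatter is therefore expected in this assay, with compound 4 estimated at 5% (range 0% to 16%), an expected step of a number 1.4 percentage points higher from compound 3 to compound 4 (within the scatter).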

Compound 4, a percentage reported as inhibition, at one concentration (the size of the read-out at that concentration, not a potency): 1.7%
The estimate for compound 4 lay 3.3 percentage points above the measured number; measured number inside the range.
By their numbers in this assay, from the lowest: compounds 4, 3, 2 and 1 (each within the scatter of the next).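

In this assay the aromatic ring on the carbon with a double bond to nitrogen can give way to isopropyl, a group with no ring, without a step beyond the scatter: from phenyl (a number 1.9 percentage points lower from compound 3 to compound 4 (within the scatter)), from 3-chlorophenyl (a number 3.3 percentage points lower from compound 2 to compound 4 (within the scatter)) and from 4-methoxyphenyl (a number 9.6 percentage points lower from compound 1 to compound 4 (within the scatter)). Across these four compounds, an aromatic ring at this place is therefore not required for the read-out to stay where it is. No data on hand speak to the reason for this result.

On these data alone, whether an amine, a carboxylic acid or a longer chain at this place would move the read-out beyond the scatter remains open.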